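Hydroxy for fluoro on the phenyl of compound 2

The source may hold more compounds than are shown below. What is called first, only, known or untested is meant among the compounds shown, and "the series" means these compounds.

Measured in a functional assay on PC-3 cells (Homo sapiens) for cytotoxicity, read by MTT assay, with a stated time of 48 h; a lower number here means a stronger inhibitor, a higher number a weaker inhibitor:
compound 1 `Cc1nc(-c2c[nH]c3ccccc23)co1` gives 337000 nM
compound 2 `Fc1ccc(-c2nc(-c3c[nH]c4ccccc34)co2)cc1` gives 42800 nM

For the measured compounds named here, compound 2 holds the lower of the two numbers in this assay; its only neighbour is compound 1, separated by the step of a 7.9-fold lower number from compound 1 to compound 2 (0.90 log units; beyond the scatter). Compound 3 `Oc1ccc(-c2nc(-c3c[nH]c4ccccc34)co2)cc1` differs from compound 2 by hydroxy in place of fluoro on an aromatic carbon, on an aromatic carbon of a six-membered aromatic ring of carbon only, para to a large group. Going by the values given here, no measured step exchanges one substituent on that phenyl for another; the single step in hand, a 7.9-fold lower number from compound 1 to compound 2 (0.90 log units; beyond the scatter), replaces methyl by the whole 4-fluorophenyl and so does not speak to a fluoro-to-hydroxy exchange. Among the compounds with values here, with no step bearing on it, compound 3 is expected to show a step of a 1.1-fold lower number from compound 2 to compound 3 (0.03 log units; within the scatter) that stays within the scatter. For compound 3 the estimate in this assay is 40000 nM, with a range from 10000 nM to 160000 nM.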

Compound 3, half-maximal inhibitory concentration: 382000 nM
Compound 3: middle estimate off by 9.6-fold (0.98 log units), on the low side, outside the stated range (above it).
By their numbers in this assay, from the lowest: compound 2; then compounds 1 and 3 (each within the scatter of the next).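

In this assay, the exchange of 4-fluorophenyl for 4-hydroxyphenyl proves far from neutral: hydroxy in place of fluoro gives an 8.9-fold higher number from compound 2 to compound 3 (0.95 log units; beyond the scatter), so a change of one heavy atom at this place, para to a large group, is enough to move the number beyond the scatter. The whole difference seen on replacing methyl with 4-fluorophenyl does not carry over to the 4-hydroxyphenyl group, since the comparison with methyl now reads a 1.1-fold higher number from compound 1 to compound 3 (0.05 log units; within the scatter), so the aryl ring alone does not secure the lower number. No measurement at hand explains why the two substituents part so sharply.

The compounds shown leave open how chloro, methoxy or an amine would read at this same place. They also leave open whether an unsubstituted phenyl would stand with compound 2 or with compound 3.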